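The source may hold more compounds than are shown below. What is called first, only, known or untested is meant among the compounds shown, and "the series" means these compounds.

Working notes on the series.

Compound 1 `Nc1cc(Cc2ccn(Cc3cccc(-c4ccccc4)c3)n2)c2nn[nH]c2n1` and compound 2 `Nc1cc(Cc2ccn(Cc3ccc4ccccc4c3)n2)c2nn[nH]c2n1` share one core and differ only in the aromatic group carried on the benzyl arm. In an assay on cells for inhibition of thyroid peroxidase (Homo sapiens), with stated times of 10 min and 15 min (a higher number here means a weaker inhibitor, a lower number a stronger inhibitor), compound 1 gives 1100 nM, and in this assay compound 2 gives 1100 nM. Compound 1 thus stands level with compound 2 at the digits shown; the two values lie within the scatter of each other, and no order between them can be read from the numbers.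

Compound 3 `Nc1cc(Cc2ccn(Cc3ccccc3)n2)c2nn[nH]c2n1` has not been measured. Relative to compound 1 it carries the change (hydrogen in place of phenyl on an aromatic carbon), a hydrogen in place of phenyl on an aromatic carbon, so the arm is cut back to a plain benzyl. Among the measured compounds shown here, no measured pair shows this cut, so the size of the step is not known from the data. The expectation for the step from compound 1 to compound 3 in this assay is a loss of some size, a 3.2-fold higher number from compound 1 to compound 3 (0.50 log units; beyond the scatter), beyond the scatter but not large. Compound 3 is accordingly estimated at 3500 nM, with a range from 1200 nM to 10000 nM.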

Compound 3, half-maximal inhibitory concentration: 2300 nM
Compound 3: the middle estimate sits 1.5-fold (0.18 log units) above what was measured, within the range that was stated.
By their numbers in this assay, from the lowest: compounds 1 and 2 (each within the scatter of the next); then compound 3.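

Among the compounds shown here, the cut from phenyl to hydrogen gives the first measured step: in this assay it reads a 2.1-fold higher number from compound 1 to compound 3 (0.32 log units; beyond the scatter), so the phenyl on this aromatic carbon counts for something, though the step is modest. Inhibition does not vanish with the phenyl, as compound 3 still gives 2300 nM with only the plain benzyl arm on the shared core. No measurement at hand bears on the reason for this step.

The compounds shown leave open whether the loss is tied to phenyl itself or whether a smaller group on the same carbon, such as methyl, methoxy or chlorine, would hold the value of compound 1. They also leave open how a group of another kind at this place, such as an amine or a carboxylic acid, would read in this assay, and whether a longer chain between the pyrazole-side nitrogen and the aromatic ring would shift the number in either direction.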